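Trifluoromethyl Exchanged for Fluoro on a Benzamide Arm

The source may hold more compounds than are shown below. What is called first, only, known or untested is meant among the compounds shown, and "the series" means these compounds.

Measured compounds:
compound 1, `CCOC(=O)c1sc(-c2cccc(NC(=O)c3ccc(F)cc3)c2)nc1Nc1ccc(N2CCN(C)CC2)cc1`, "not determined" (no result reported);
compound 2, `CN1CCN(c2ccc(Nc3nc(-c4cccc(NC(=O)c5ccc(C(F)(F)F)cc5)c4)sc3C(N)=O)cc2)CC1`, 3210 nM.

Compound 1 carries the same 4-fluorophenyl benzamide arm that compound 3 will carry, but on a different core end-group, and no number was recorded for it. Compound 2 therefore stands as the only measured point: in a functional assay on Raji cells (Homo sapiens) for antiproliferative activity, read by CCK-8 assay, with a stated time of 72 h (on this read-out higher numbers stand for weaker inhibition and lower numbers for stronger inhibition), compound 2 gives 3210 nM, a modest inhibition, and there is nothing in the set to rank it against.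

Compound 3, `CN1CCN(c2ccc(Nc3nc(-c4cccc(NC(=O)c5ccc(F)cc5)c4)sc3C(N)=O)cc2)CC1`, differs from compound 2 in one place only: fluoro in place of trifluoromethyl on an aromatic carbon. For the measured compounds named here, no step between two measured compounds is available, so the size of this change has no precedent within the study. The exchange keeps every other part of the molecule intact, and a shift of this kind is expected to stay within the usual scatter, if anything leaning toward slightly weaker inhibition; the estimated step is a 1.2-fold higher number from compound 2 to compound 3 (0.10 log units; within the scatter). Compound 3 is expected to give about 4000 nM in this assay, with a plausible range from 1300 nM to 12000 nM.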

Compound 3, half-maximal inhibitory concentration: 2820 nM
Compound 3: middle estimate off by 1.4-fold (0.15 log units), on the high side; the measured number falls inside the stated range.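

The exchange of 4-(trifluoromethyl)phenyl for 4-fluorophenyl provides the first step measured between two compounds in this set: in this assay, it amounts to a 1.1-fold lower number from compound 2 to compound 3 (0.06 log units; within the scatter). At this aromatic carbon, para to a large group, the read-out therefore does not separate trifluoromethyl from fluoro, and the two compounds cannot be ranked against each other. No measurement is available to explain this result.

From the compounds shown here alone, the two values cover only these two groups at this position, so it remains open whether an amine, a methoxy group or a carboxylic acid on the same aromatic carbon would move the number in this assay beyond the scatter. Compound 1 carries an ethyl ester where compound 3 carries a carboxamide, but with compound 1 recorded as "not determined" (no result reported), the step between this ester and the carboxamide cannot be read.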